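Ester-side variation on the shared core of compound 1

This account rests on a few compounds, and the source may have more. Where it says the series, first, only, none or still open, it means among the compounds named here.

Compound 1 `Cc1c(C(=O)OC(C)C(C)(C)C)c[nH]c1C(=O)OC(C)CN(C)C` gives 390 nM in an assay on CHO cells for inhibition of metabotropic glutamate receptor 1 (Rattus norvegicus); on this read-out higher numbers stand for weaker inhibition and lower numbers for stronger inhibition. For the measured compounds named here, compound 2 `CCN1CCC(OC(=O)c2[nH]cc(C(=O)OC(C)C(C)(C)C)c2C)C1` gives 260 nM in this assay, and the step of a 1.5-fold lower number from compound 1 to compound 2 (0.18 log units; within the scatter) is within the scatter, so compound 2 and compound 1 sit together on the two numbers so far. Compound 3 `Cc1c(C(=O)OC(C)C(C)(C)C)c[nH]c1C(=O)OC(C)(C)C` carries the change (tert-butyl in place of 1-ethylpyrrolidin-3-yl on an oxygen next to a carbonyl group). Going by the values given here, only the step of a 1.5-fold lower number from compound 1 to compound 2 (0.18 log units; within the scatter) touches the same oxygen, and it exchanged one acceptor-bearing group for another; no measured step removes the acceptor. The expectation for compound 3 is therefore a step of a 2.3-fold higher number from compound 2 to compound 3 (0.36 log units; beyond the scatter) of uncertain direction, with wide bounds. Compound 3 is estimated at 600 nM, expected between 200 nM and 2500 nM.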

Compound 3, half-maximal inhibitory concentration: 17 nM
For compound 3 the middle estimate is 35-fold (1.55 log units) above the measured one; the whole stated range lies above it.
By their numbers in this assay, from the lowest: compound 3; then compounds 2 and 1 (each within the scatter of the next).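

On an oxygen next to a carbonyl group, tert-butyl in place of 1-ethylpyrrolidin-3-yl gives a 15-fold lower number from compound 2 to compound 3 (1.18 log units; beyond the scatter) in this assay, and in place of 1-((dimethylamino)methyl)ethyl it gives a 23-fold lower number from compound 1 to compound 3 (1.36 log units; beyond the scatter) on the same read-out. This position therefore does respond strongly to the group it carries, although the two nitrogen-bearing groups of compound 1 and compound 2 did not separate beyond the scatter. No measurement available here explains the size of this change.

The compounds shown leave open whether the step follows the loss of nitrogen or tert-butyl itself. Cyclopentyl or n-butyl on the same oxygen would separate these two readings.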